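This account rests on a few compounds, and the source may have more. Where it says the series, first, only, none or still open, it means among the compounds named here.

Three compounds share one core and were tested in a functional assay on HL-60 cells (Homo sapiens) for inhibition, read by MTT assay, with a stated time of 72 h; on this read-out higher numbers stand for weaker inhibition and lower numbers for stronger inhibition. Compound 1 `Cc1ccc(-n2cc(-c3ccc(CN4CCN(C)CC4)c(C(F)(F)F)c3)nn2)cc1Nc1nccc(-c2cccnc2)n1` gives 20 nM; compound 2 `Cc1ccc(-c2nnc(-c3ccc(CN4CCN(C)CC4)cc3)o2)cc1Nc1nccc(-c2cccnc2)n1` gives 570 nM; compound 3 `Cc1ccc(-c2nnc(-c3ccc(CN4CCN(C)CC4)c(C(F)(F)F)c3)o2)cc1Nc1nccc(-c2cccnc2)n1` gives 50 nM, the second highest of the three numbers, with compound 1 lower and compound 2 higher. Among the measured compounds shown here, the only single-point step recorded is an 11-fold lower number from compound 2 to compound 3 (1.06 log units; beyond the scatter). Compound 4 `Cc1ccc(-c2nnc(-c3ccc(CN4CCN(CCN=C=S)CC4)c(C(F)(F)F)c3)o2)cc1Nc1nccc(-c2cccnc2)n1` differs from compound 3 by a group of 4 heavy atoms (2 carbon, 1 nitrogen, 1 sulfur; no ring) in place of a hydrogen atom, on a saturated chain carbon bound to an amine nitrogen in a ring. For the measured compounds named here, no measured pair shows this kind of change, so the trifluoromethyl step offers no direct guide, and the piperazine chain is untouched in every measured compound. Compound 4 is therefore expected to change little, with a 1.2-fold higher number from compound 3 to compound 4 (0.08 log units; within the scatter), an estimated 60 nM in a range of 15 nM to 250 nM.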

Compound 4, half-maximal inhibitory concentration: 70 nM
Estimate against measurement, compound 4: 1.2-fold (0.07 log units) below, within the range that was stated.
By their numbers in this assay, from the lowest: compound 1; then compounds 3 and 4 (each within the scatter of the next); then compound 2.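

In this assay the step is a 1.4-fold higher number from compound 3 to compound 4 (0.15 log units; within the scatter) and so a group of 4 heavy atoms (2 carbon, 1 nitrogen, 1 sulfur; no ring) can enter on a saturated chain carbon bound to an amine nitrogen in a ring without a readable change in the number. The earlier compounds shown here left this position unchanged, so they could not show this tolerance. Nothing available here accounts for the result.

As far as these compounds go, whether a longer chain, or a chain ending in a carboxylic acid or a primary amine, would also hold the number remains open. So does whether the same group would behave alike on the core of compound 1.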